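This account rests on a few compounds, and the source may have more. Where it says the series, first, only, none or still open, it means among the compounds named here.

Compound 3 `Cc1cc(C)cc(-n2nncc2CN2C(=O)C3(C(C#N)=C(N)Oc4c(N)cc5nc6ccccc6nc5c43)c3ccccc32)c1` is one of three close relatives that share the same core and differ only in the aryl group on the triazole nitrogen. In a functional assay on HCT-116 cells (Homo sapiens) for antiproliferative activity, read by MTT assay, with a stated time of 48 h (a lower number here means a stronger inhibitor, a higher number a weaker inhibitor), compound 3 gives only a limit, > 50000 nM, not a number. Compound 2 `CC(=O)Nc1ccc(-n2nncc2CN2C(=O)C3(C(C#N)=C(N)Oc4c(N)cc5nc6ccccc6nc5c43)c3ccccc32)cc1` likewise gives only a limit in this assay, > 50000 nM. For the measured compounds named here, compound 1 `CCc1ccccc1-n1nncc1CN1C(=O)C2(C(C#N)=C(N)Oc3c(N)cc4nc5ccccc5nc4c32)c2ccccc21` is the one member of the trio with a measured number, 10300 nM in this assay. From compound 1 the change to a 4-acetamidophenyl group is an at least 4.8-fold higher number from compound 1 to compound 2 (0.68 log units; beyond the scatter), and the change to a 3,5-dimethylphenyl group is an at least 4.8-fold higher number from compound 1 to compound 3 (0.68 log units; beyond the scatter); between the two limits the step that the two limits leave unreadable from compound 2 to compound 3. Two of the three compounds therefore sit at the same ceiling, (the limit of > 50000 nM in this assay, at which 2 of the 3 values shown sit), and compound 3 stands there too.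

Compound 4 `N#CC1=C(N)Oc2c(N)cc3nc4ccccc4nc3c2C12C(=O)N(Cc1cnnn1-c1ccc(Cl)cc1[N+](=O)[O-])c1ccccc12` makes the change (4-chloro-2-nitrophenyl in place of 3,5-dimethylphenyl on an aromatic nitrogen). The two measured steps that touch this position both ran toward the ceiling, and neither tells how a 4-chloro-2-nitrophenyl group would behave; no comparison reaches past the limit. For compound 4 the expected outcome in this assay is therefore 40000 nM, spanning 10000 nM to 100000 nM, most likely again reported as a limit. The step expected from compound 3 to compound 4 is an at least 1.2-fold lower number from compound 3 to compound 4 (0.09 log units; that floor lies within the scatter).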

Compound 4, half-maximal inhibitory concentration: 28700 nM
Estimate against measurement, compound 4: 1.4-fold (0.14 log units) above, within the range that was stated.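

Compound 4 gives a measured number in this assay, so this aromatic nitrogen can carry a group other than 2-ethylphenyl without the result reaching the ceiling, where compound 2 and compound 3 each stand at a limit: the limit of > 50000 nM in this assay, at which 2 of the 4 values shown sit.

The size of the gain over those two compounds stays uncertain, since only floors can be given, an at least 1.7-fold lower number from compound 3 to compound 4 (0.24 log units; that floor lies within the scatter) and an at least 1.7-fold lower number from compound 2 to compound 4 (0.24 log units; that floor lies within the scatter), and neither floor clears the usual scatter. Compound 1 keeps the lower number, with a 2.8-fold higher number from compound 1 to compound 4 (0.45 log units; beyond the scatter), and among these four compounds only, the two groups that give a number, 2-ethylphenyl and 4-chloro-2-nitrophenyl, both have a substituent numbered 2 in their names, while 4-acetamidophenyl and 3,5-dimethylphenyl do not.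

With so few groups, this link rests on two numbers, and the compounds shown cannot separate the part played by the 2-substituent from that of the chlorine in compound 4. From the compounds shown here alone, it also remains open what a plain phenyl group, a 2-aminophenyl group or a longer alkyl chain on this nitrogen would give.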